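Compound 3 in a series known only by limits

The source may hold more compounds than are shown below. What is called first, only, known or untested is meant among the compounds shown, and "the series" means these compounds.

Compound 1 `NNC(=O)CCc1ccncc1-c1ccc2ccccc2c1`: > 10000 nM
Compound 2 `CNC(=O)/C=C/c1ccncc1-c1ccc2cc[nH]c2c1`: > 10000 nM

In a functional assay on KB cells (Homo sapiens) for inhibition, read by sulforhodamine B assay, with a stated time of 72 h (on this read-out higher numbers stand for weaker inhibition of growth and lower numbers for stronger inhibition of growth), compound 1 gives > 10000 nM, which is a limit of the assay and not a number. Compound 2 gives > 10000 nM, which is also a limit. The position of compound 1 is therefore (the limit of > 10000 nM in this assay, at which 2 of the 2 values shown sit).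

Compound 3 `CN(C)C(=O)/C=C/c1ccncc1-c1ccc2ccccc2c1` is the next to be read. It keeps the core of compound 1 and changes one substituent: 2-(dimethylcarbamoyl)ethenyl in place of 2-(aminocarbamoyl)ethyl on an aromatic carbon. 2-(Dimethylcarbamoyl)ethenyl takes the place of 2-(aminocarbamoyl)ethyl on an aromatic carbon, ortho to a large group and opposite the ring nitrogen.

Within the data shown here, no measured step is available to scale this change. No step beyond the usual scatter is expected in this assay, in either direction, and a further limit is the likeliest report. This expectation rests on compound 1, whose > 10000 nM is a limit. The expected step is a step that the limit leaves unreadable from compound 1 to compound 3. For compound 3 the estimate is 12000 nM, with an expected range of 4000 nM to 30000 nM.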

Compound 3, concentration for 50% growth inhibition: 7760 nM
Compound 3: middle estimate off by 1.5-fold (0.19 log units), on the high side; the range from low to high includes it.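

In this assay, among these compounds, compound 3 gives 7760 nM, the only value shown that is not a limit of the assay, so this position can carry a group that gives a readable number on the shared core. Placing 2-(dimethylcarbamoyl)ethenyl instead of 2-(aminocarbamoyl)ethyl on this aromatic carbon, ortho to a large group and opposite the ring nitrogen, gives an at least 1.2-fold lower number from compound 1 to compound 3 (0.11 log units; that floor lies within the scatter), and that floor alone does not establish a gain in growth inhibition. The value for compound 1 is a limit of the assay, so the full size of the step cannot be read: the limit of > 10000 nM in this assay, at which 2 of the 3 values shown sit.

The change alters the link and the amide end together, the ethenyl for the ethyl and the dimethylamide for the hydrazide, and the compounds shown do not separate the two; 2-(dimethylcarbamoyl)ethyl at the same place would do so. Also open, on these data alone, is how the number would respond to a carboxylic acid, an amine or a longer chain at this position.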